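The source may hold more compounds than are shown below. What is called first, only, known or untested is meant among the compounds shown, and "the series" means these compounds.

Measured in an ADME assay on MDBK cells (Bos taurus) for cytotoxicity; on this read-out higher numbers stand for lower toxicity in this test and lower numbers for higher toxicity in this test:
Compound 1 `COc1cccc(Cn2ccc3nc(-c4ccccc4)nc-3c2)c1` gives > 100000 nM
Compound 2 `Brc1cccc(Cn2ccc3nc(-c4ccccc4)nc-3c2)c1` gives 85000 nM
Compound 3 `N#Cc1cccc(Cn2ccc3nc(-c4ccccc4)nc-3c2)c1` gives > 100000 nM

Compound 3 shows > 100000 nM as a limit of the assay, not a number. Compound 1 shows > 100000 nM as a limit too. Compound 2 alone gives a number, 85000 nM in this series. The series is therefore read mainly through the limit of > 100000 nM in this assay, at which 2 of the 3 values shown sit, and that single number.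

Compound 4 `FC(F)(F)c1cccc(Cn2ccc3nc(-c4ccccc4)nc-3c2)c1` keeps the shared core, with trifluoromethyl in place of cyano on an aromatic carbon, a swap counted as trifluoromethyl in place of cyano on an aromatic carbon in full.

Three measured swaps on an aromatic carbon bear on this change. Bromo in place of methoxy gave an at least 1.1-fold lower number from compound 1 to compound 2 (0.07 log units; that floor lies within the scatter) as one step. Cyano in place of bromo gave an at least 1.1-fold higher number from compound 2 to compound 3 (0.07 log units; that floor lies within the scatter) as another. Cyano in place of methoxy gave a step that the two limits leave unreadable from compound 1 to compound 3 and so adds no size.

Neither readable floor goes beyond the scatter, so no step beyond the scatter is expected, and the assay may again report only a limit. The estimated change is an at least 1.1-fold lower number from compound 3 to compound 4 (0.04 log units; that floor lies within the scatter) in size. For compound 4 the estimate is 90000 nM as the expected value, with an expected range from 50000 nM to 130000 nM overall.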

Compound 4, half-maximal cytotoxic concentration: 98000 nM
The estimate for compound 4 lay 1.1-fold (0.04 log units) below the measured number; the measured number falls inside the stated range.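

In this assay, trifluoromethyl in place of bromo on this aromatic carbon gives the only step shown between two actual numbers, a 1.2-fold higher number from compound 2 to compound 4 (0.06 log units; within the scatter), so the size of a swap at this position can now be read directly rather than as a floor. Against the two compounds held at a limit, only floors can be read, and both stay within the scatter: an at least 1.0-fold lower number from compound 3 to compound 4 (0.00 log units; that floor lies within the scatter) for trifluoromethyl in place of cyano, and an at least 1.0-fold lower number from compound 1 to compound 4 (0.00 log units; that floor lies within the scatter) for trifluoromethyl in place of methoxy. Even this swap, which removes a triple bond and the hydrogen-bond acceptor counted for cyano, produces no readable step beyond the scatter, and the series remains tied to one assay limit: the limit of > 100000 nM in this assay, at which 2 of the 4 values shown sit.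

From the compounds shown here alone, how far compound 1 and compound 3 truly lie from compound 4 stays open, as a limit gives a floor for the step and no exact size. Also open, going by these compounds, is whether a group of another kind at this position, such as an amine or a carboxylic acid, would move the read-out beyond the scatter.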